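Removing the ring hydroxyl from a lactone-bearing inhibitor

The source may hold more compounds than are shown below. What is called first, only, known or untested is meant among the compounds shown, and "the series" means these compounds.

Measured so far:
Compound 1 `C[C@]1(O)CC(=O)OC(CSc2nc(-c3ccccc3)c(-c3ccccc3)[nH]2)C1`: 140 nM
Compound 2 `CC1=CC(=O)OC(CSc2nc(-c3ccc(C)cc3)c(-c3ccc(C)cc3)[nH]2)C1`: 280 nM

In an assay on microsomes from liver for inhibition of sterol O-acyltransferase 1 (Rattus norvegicus) (a lower number here means a stronger inhibitor, a higher number a weaker inhibitor), compound 1 gives 140 nM. Compound 2, which carries a different lactone ring and methyl groups on both phenyl rings, gives 280 nM in this assay; the two numbers lie within the usual scatter of each other, so they cannot be told apart. Compound 3 `CC1(C)CC(=O)OC(CSc2nc(-c3ccccc3)c(-c3ccccc3)[nH]2)C1` keeps the shared core of compound 1 and changes only the lactone ring: a group of 9 heavy atoms (7 carbon, 2 oxygen; one six-membered non-aromatic ring with 1 hetero atom) in place of a group of 9 heavy atoms (6 carbon, 3 oxygen; one six-membered non-aromatic ring with 1 hetero atom), on a saturated chain carbon bound to a sulfur. The hydroxyl is lost and a second methyl is gained. Among the compounds with values here, no measured pair shows what such a change does to this assay, so there is nothing to lean on beyond the value of compound 1. A step of a 1.4-fold higher number from compound 1 to compound 3 (0.15 log units; within the scatter) is expected, small and in either direction, likely within the scatter. Compound 3 is therefore estimated at 200 nM, with a range of 70 nM to 600 nM.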

Compound 3, half-maximal inhibitory concentration: 100 nM
Compound 3: the middle estimate sits 2.0-fold (0.30 log units) above what was measured; low and high end bracket the measured number.
By their numbers in this assay, from the lowest: compounds 3, 1 and 2 (each within the scatter of the next, the first and the last beyond it).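

In this assay, within the data shown here, replacing the ring hydroxyl with a second methyl gives a 1.4-fold lower number from compound 1 to compound 3 (0.15 log units; within the scatter), the first step at this position that changes only one place. The pair shows that a lactone ring with no hydrogen-bond donor and no defined stereocentre still gives a number that cannot be told apart from that of the hydroxyl-bearing ring, so at this level of resolution the hydroxyl shows no measurable contribution. No measurement at hand bears on why the swap leaves the number within the scatter. Still open, as far as these compounds go, is what an amine or a longer chain such as ethyl would do in place of the hydroxyl. Also open, from the compounds shown here alone, is whether a carboxylic acid in place of the whole lactone ring would keep a number in this range.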